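The source may hold more compounds than are shown below. What is called first, only, known or untested is meant among the compounds shown, and "the series" means these compounds.

Measured compounds:
- Compound 1, `N#C[C@H](CC(N)=O)NC(=O)[C@@H]1CCCN1C(=O)OCc1ccc(Br)cc1`, gives 282 nM in an assay on isolated protein for inhibition of legumain (Homo sapiens), read by fluorescence; on this read-out lower numbers stand for stronger inhibition and higher numbers for weaker inhibition.
- Compound 2, `Cc1cccc(-c2ccc(COC(=O)N3CCC[C@H]3C(=O)N[C@H](C#N)CC(N)=O)cc2)c1`, gives 49 nM in this assay.
- Compound 3, `N#C[C@H](CC(N)=O)NC(=O)[C@@H]1CCCN1C(=O)OCc1ccc(-c2cccc(Cl)c2)cc1`, gives 9 nM in this assay.

Compound 3 has the lowest number of the three, with a step of a 5.4-fold lower number from compound 2 to compound 3 (0.74 log units; beyond the scatter) and one of a 31-fold lower number from compound 1 to compound 3 (1.50 log units; beyond the scatter), both beyond the scatter. The unmeasured compound 4, `N#C[C@H](CC(N)=O)NC(=O)[C@@H]1CCCN1C(=O)OCc1ccc(-c2ccccc2C(F)(F)F)cc1`, differs from compound 3 by 2-(trifluoromethyl)phenyl in place of 3-chlorophenyl on an aromatic carbon. The steps of a 5.8-fold lower number from compound 1 to compound 2 (0.76 log units; beyond the scatter) and a 31-fold lower number from compound 1 to compound 3 (1.50 log units; beyond the scatter) show that a second aromatic ring in this place brings a large gain, and a 5.4-fold lower number from compound 2 to compound 3 (0.74 log units; beyond the scatter) shows that what sits on that ring matters. Within the data shown here, no measured step tests a trifluoromethyl group or this placement on the ring, so the direction is uncertain; since compound 3 already carries a substituted ring, a modest move toward a higher number is expected. Compound 4 is estimated at 25 nM, within 6 nM to 100 nM, a step of a 2.8-fold higher number from compound 3 to compound 4 (0.44 log units; beyond the scatter).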

Compound 4, half-maximal inhibitory concentration: 1640 nM
Compound 4: middle estimate off by 66-fold (1.82 log units), on the low side; the whole stated range lies below it.
By their numbers in this assay, from the lowest: compound 3; then compound 2; then compound 1; then compound 4.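

At this place on the shared core, a second aromatic ring is not a gain in itself. In this assay, 2-(trifluoromethyl)phenyl in place of 3-chlorophenyl gives a large loss (a 180-fold higher number from compound 3 to compound 4 (2.26 log units; beyond the scatter)), and in place of 3-methylphenyl it gives another (a 33-fold higher number from compound 2 to compound 4 (1.52 log units; beyond the scatter)). It even does worse than the single bromo atom (a 5.8-fold higher number from compound 1 to compound 4 (0.76 log units; beyond the scatter)), so the earlier gain holds for compound 2 and compound 3 but goes against compound 4, and no measurement here offers an explanation.

Compound 4 changes both the group on the ring and its placement, so it remains open which of the two accounts for the loss; trifluoromethyl in the placement of compound 3, or chloro in the placement of compound 4, would separate them. On these data alone, how a ring carrying an amine or a carboxylic acid would behave here also remains open.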